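The compounds below may be only part of what the source reports. "The series", "measured", "known", "first", "only" and "open" are said of these compounds alone.

Compound 1 `O=C(/C(=C\c1c[nH]c2ccc(Cl)cc12)SCc1ccc(F)cc1)c1ccc(Br)cc1` gives 1000 nM in a functional assay on DU-145 cells (Homo sapiens) for inhibition, read by trypan blue exclusion, with a stated time of 96 h; a higher number here means a weaker inhibitor of growth, a lower number a stronger inhibitor of growth. It stands level with compound 2 `Cc1ccc(S/C(=C/c2c[nH]c3ccc(Cl)cc23)C(=O)c2ccc(Br)cc2)cc1`, which gives 1000 nM, the two together holding the lowest of the three numbers, and no change at the digits printed from compound 1 to compound 2 (within the scatter). Compound 3 `Cc1ccc(S(=O)(=O)/C(=C/c2c[nH]c3ccc(Cl)cc23)C(=O)c2ccc(Br)cc2)cc1` gives 10000 nM; there a 10-fold higher number from compound 1 to compound 3 (1.00 log units; beyond the scatter), and likewise a 10-fold higher number from compound 2 to compound 3 (1.00 log units; beyond the scatter). Compound 4 `Cc1ccsc1/C=C(/SCc1ccc(F)cc1)C(=O)c1ccc(Br)cc1` differs from compound 1 at another place: 3-methylthiophen-2-yl in place of 5-chloro-1H-indol-3-yl on a double-bonded chain carbon bound to a double-bonded chain carbon. Within the data shown here, none of the measured steps alters that position; all three concern the group on the sulfur, so they offer no direct guide to this change, and the hydrogen-bond donor counted as leaving is weighed only loosely. Compound 4 is expected to show a 3.0-fold higher number from compound 1 to compound 4 (0.48 log units; beyond the scatter). The value of compound 4 in this assay is estimated at 3000 nM, within 1000 nM to 10000 nM.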

Compound 4, concentration for 50% growth inhibition: 50000 nM
Beside the measured number, compound 4's estimate is 17-fold (1.22 log units) below it, outside the stated range (above it).
By their numbers in this assay, from the lowest: compounds 1 and 2 (each within the scatter of the next); then compound 3; then compound 4.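

In this assay, the change at this position carries a large penalty: a 50-fold higher number from compound 1 to compound 4 (1.70 log units; beyond the scatter), with 3-methylthiophen-2-yl in place of 5-chloro-1H-indol-3-yl. Among these compounds, the earlier steps touched only the group on the sulfur, so this is the first sign that activity also depends on the group on the double-bonded chain carbon. No evidence at hand explains the loss. The swap alters the ring count, the chlorine and the hydrogen-bond donor together, and these compounds do not separate them. Going by these compounds, how 5-methoxy-1H-indol-3-yl or 1H-indol-3-yl without the chlorine would compare remains open.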